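Extending the Amine Chain of Compound 1

This account rests on a few compounds, and the source may have more. Where it says the series, first, only, none or still open, it means among the compounds named here.

Compound 1 `Cc1ccc2oc(-c3ccc(NC(=O)CN4CCN(CCN(C)C)CC4)c(C)c3)nc2c1` gives 16700 nM in a functional assay on C6 cells (Rattus norvegicus) for cytotoxicity, read by MTT assay, with a stated time of 24 h (a higher number here means a weaker inhibitor, a lower number a stronger inhibitor), the highest of the three numbers recorded. Compound 3 `Cc1cc(-c2nc3cc(F)ccc3o2)ccc1NC(=O)CN1CCN(CCN(C)C)CC1` gives 10700 nM, and compound 2 `CN(C)CCN1CCN(CC(=O)Nc2ccc(-c3nc4cc(F)ccc4o3)cc2)CC1` gives 4390 nM. The change from compound 1 to compound 3 is a 1.6-fold lower number from compound 1 to compound 3 (0.19 log units; within the scatter), while that from compound 2 to compound 3 is a 2.4-fold higher number from compound 2 to compound 3 (0.39 log units; beyond the scatter); both alter the aromatic part of the shared core. Compound 4 `Cc1ccc2oc(-c3ccc(NC(=O)CN4CCN(CCCN(C)C)CC4)c(C)c3)nc2c1` differs from compound 1 at the chain instead: (dimethylamino)methyl in place of dimethylamino on a saturated chain carbon, two bonds along the chain from an amine nitrogen in a ring. No measured step touches this chain, so nothing among these compounds argues for a shift beyond the scatter in this assay. Compound 4 is therefore expected to give about 16000 nM, between 6000 nM and 45000 nM, an estimated step of a 1.0-fold lower number from compound 1 to compound 4 (0.02 log units; within the scatter).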

Compound 4, half-maximal inhibitory concentration: 7320 nM
Compound 4: middle estimate off by 2.2-fold (0.34 log units), on the high side; low and high end bracket the measured number.
By their numbers in this assay, from the lowest: compounds 2, 4, 3 and 1 (each within the scatter of the next, the first and the last beyond it).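

Placing (dimethylamino)methyl in place of dimethylamino on this saturated chain carbon gives a 2.3-fold lower number from compound 1 to compound 4 (0.36 log units; beyond the scatter) in this assay. The step is modest, but it shows that the number responds to a change in the chain and not only to changes in the aromatic part of the shared core. Nothing available explains this shift.

From the compounds shown here alone, whether a longer chain ending in 3-(dimethylamino)propyl would continue this trend remains open, as does the effect of a diethylamino group at the chain end. Going by these compounds, it is also open whether the same extension would give a similar step on compound 2 or compound 3.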